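The compounds below may be only part of what the source reports. "The series", "measured", "known", "first", "only" and "open" are said of these compounds alone.

Compound 1 `COc1ccccc1N1CCN(CCCNC(=O)Cc2c[nH]c3ccccc23)CC1`: 513 nM
Compound 2 `COc1ccccc1N1CCN(CCCNC(=O)CCc2c[nH]c3ccccc23)CC1`: 219 nM

Among the compounds with values here, in an assay on isolated protein (spleen, strain Sprague-Dawley) for antagonist activity at Alpha-1B adrenergic receptor (Rattus norvegicus), with a stated time of 20 min (a lower number here means tighter binding, a higher number weaker binding), compound 1 gives 513 nM, while compound 2 gives 219 nM, the lowest of the two numbers measured so far. Within the data shown here, the single measured step, a 2.3-fold lower number from compound 1 to compound 2 (0.37 log units; beyond the scatter), is modest in size but does lie beyond the usual scatter; it came from lengthening the saturated link between the carbonyl and the indole by one carbon.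

Compound 3 `COc1ccccc1N1CCN(CCCNC(=O)CCCc2c[nH]c3ccccc23)CC1` carries that idea one step further. Its difference from compound 2 is (1H-indol-3-yl)methyl in place of 1H-indol-3-yl on a saturated chain carbon, two bonds along the chain from a carbonyl carbon, so the indole now sits one carbon further from the carbonyl than in compound 2. Among the measured compounds shown here, the only step that bears on this is the one from compound 1 to compound 2, which pointed toward a lower number. Whether a second lengthening acts the same way cannot be read from two compounds; the step from compound 2 to compound 3 is therefore expected to be small, at most a further modest lowering, and may well fall within the scatter, giving an expected 1.5-fold lower number from compound 2 to compound 3 (0.16 log units; within the scatter). On that basis compound 3 is estimated at 150 nM in this assay, with a range from 60 nM to 450 nM.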

Compound 3, dissociation constant: 95.5 nM
Beside the measured number, compound 3's estimate is 1.6-fold (0.20 log units) above it, and the stated range covers the measured number.
By their numbers in this assay, from the lowest: compound 3; then compound 2; then compound 1.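

In this assay the change to (1H-indol-3-yl)methyl on a saturated chain carbon, two bonds along the chain from a carbonyl carbon, gives a 2.3-fold lower number from compound 2 to compound 3 (0.36 log units; beyond the scatter), which matches in size the earlier 2.3-fold lower number from compound 1 to compound 2 (0.37 log units; beyond the scatter). The first lengthening of the chain is therefore no isolated case: across these three compounds, each added carbon lowers the number by a similar amount, none of them goes against this, and compound 3 at 95.5 nM has the lowest number of the set. Nothing shown here gives a cause for this trend, whether from a measured property of the compounds or from any other data.

Three compounds cannot show where the trend ends, so a still longer saturated chain between the carbonyl and the indole might lower the number further, level off or raise it. On these data alone, it also remains open whether the same lengthening would have a similar effect with a different group at the end of the chain, such as a plain phenyl ring in place of the indole.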